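The compounds below may be only part of what the source reports. "The series", "measured", "known", "first", "only" and "open" are said of these compounds alone.

Measured in a functional assay on QGY-7703 cells (Homo sapiens) for cytotoxicity, read by MTT assay, with a stated time of 24 h; a lower number here means a stronger inhibitor, a higher number a weaker inhibitor:
- Compound 1 `O=C1/C(=C/c2ccccc2F)CN(S(=O)(=O)c2ccc(F)cc2)C/C1=C\c1ccccc1F`: 8500 nM
- Compound 2 `N#Cc1ccc(/C=C2\CN(S(=O)(=O)c3ccc(F)cc3)C/C(=C\c3ccc(C#N)cc3)C2=O)cc1`: 11300 nM
- Compound 3 `O=C1/C(=C/c2cccc([N+](=O)[O-])c2)CN(S(=O)(=O)c2ccc(F)cc2)C/C1=C\c1ccccc1F`: 14900 nM

At 14900 nM, compound 3 lies within the scatter of both other compounds, so these three values cannot be ranked with confidence.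

The next compound, compound 4 `N#Cc1ccc(/C=C2\CN(S(=O)(=O)c3ccc(F)cc3)C/C(=C\c3ccccc3F)C2=O)cc1`, has 4-cyanophenyl in place of 3-nitrophenyl on a double-bonded chain carbon bound to a double-bonded ring carbon. For the measured compounds named here, the one measured step that bears on this swap is a 1.8-fold higher number from compound 1 to compound 3 (0.24 log units; within the scatter), which exchanged 2-fluorophenyl for 3-nitrophenyl at this kind of place. Compound 4 also keeps the 2-fluorophenyl of compound 1 (8500 nM) and carries the 4-cyanophenyl of compound 2 (11300 nM). With so few data, a value near these two seems the reasonable expectation, and no change beyond the scatter is expected in this assay. The expected step is a 1.5-fold lower number from compound 3 to compound 4 (0.17 log units; within the scatter). For compound 4 the estimated value is 10000 nM, with an expected range from 5500 nM to 18000 nM.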

Compound 4, half-maximal inhibitory concentration: 20100 nM
The estimate for compound 4 lay 2.0-fold (0.30 log units) below the measured number; measured number above the stated range.
By their numbers in this assay, from the lowest: compounds 1, 2, 3 and 4 (each within the scatter of the next, the first and the last beyond it).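

In this assay, for the compounds shown here, replacing 2-fluorophenyl with 4-cyanophenyl at this place gives the first step that lies beyond the scatter: a 2.4-fold higher number from compound 1 to compound 4 (0.37 log units; beyond the scatter), a modest loss of strength. The other two steps do not separate their compounds: a 1.3-fold higher number from compound 3 to compound 4 (0.13 log units; within the scatter), so 4-cyanophenyl and 3-nitrophenyl cannot be told apart here, and a 1.8-fold higher number from compound 2 to compound 4 (0.25 log units; within the scatter), so exchanging a 4-cyanophenyl for 2-fluorophenyl with the other 4-cyanophenyl in place has no clear effect. No measurement at hand explains the modest step.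

The compounds shown leave open how a phenyl group carrying an amine or a carboxylic acid would behave at this place. They also leave open whether an unsubstituted phenyl would match compound 1 or compound 4.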